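This account rests on a few compounds, and the source may have more. Where it says the series, first, only, none or still open, it means among the compounds named here.

Working notes on the series, single-point changes on the urea-bearing aryl group.

Compound 1 `COc1cc(Nc2ncnc3c(NC(=O)Nc4cc(Cl)cc(Cl)c4)cccc23)cc(OC)c1` is the reference. In a functional assay on RT-112 cells (Homo sapiens) for antiproliferative activity, read by MTT assay, with a stated time of 72 h (on this read-out higher numbers stand for weaker inhibition of growth and lower numbers for stronger inhibition of growth), compound 1 gives 30.2 nM, the lowest of the three numbers measured. Compound 2 `COc1cc(Nc2ncnc3c(NC(=O)Nc4cc(F)cc(F)c4)cccc23)cc(OC)c1` gives 2630 nM in this assay, and compound 3 `COc1cc(Nc2ncnc3c(NC(=O)Nc4cccc(Cc5ccccc5)c4)cccc23)cc(OC)c1` gives 1740 nM. Among the measured compounds shown here, the one step measured in one place, an 87-fold higher number from compound 1 to compound 2 (1.94 log units; beyond the scatter), shows that the pair of halogens on this ring is not interchangeable: exchanging both chlorines for fluorines costs a great deal. Compound 3 carries a different group on the same ring and also lies far from compound 1, though no single-step comparison is available for it.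

Compound 4 `COc1cc(Nc2ncnc3c(NC(=O)Nc4ccc(Cl)c(Cl)c4)cccc23)cc(OC)c1` differs from compound 1 by 3,4-dichlorophenyl in place of 3,5-dichlorophenyl on an amide-type nitrogen. The atoms are the same; only the placement of one chlorine moves. For the measured compounds named here, none of the measured steps bears directly on a change of placement alone, and the only step that does touch the halogens, from compound 1 to compound 2, concerns their identity rather than their position. The measured numbers show that this assay reacts strongly to what sits on this ring, so some weakening in this assay is expected for compound 4, but of uncertain size. Compound 4 is estimated at 150 nM, within 25 nM to 1500 nM, which as a step is a 5.0-fold higher number from compound 1 to compound 4 (0.70 log units; beyond the scatter).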

Compound 4, concentration for 50% growth inhibition: 6230 nM
For compound 4 the middle estimate is 42-fold (1.62 log units) below the measured one; the whole stated range lies below it.
By their numbers in this assay, from the lowest: compound 1; then compounds 3 and 2 (each within the scatter of the next); then compound 4.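

Moving one chlorine is enough to change the result on this ring: with the atoms unchanged, the exchange of 3,5-dichlorophenyl for 3,4-dichlorophenyl on the urea nitrogen gives a 210-fold higher number from compound 1 to compound 4 (2.31 log units; beyond the scatter). The earlier step showed that the identity of the halogens matters, and this one shows that their placement matters independently, so chlorine alone does not secure the low number of compound 1 in this assay. Compound 4 also falls behind the 3,5-difluorophenyl analogue, with a 2.4-fold higher number from compound 2 to compound 4 (0.37 log units; beyond the scatter), so among these compounds a 3,5-difluorophenyl group does better than chlorines in the 3,4-dichlorophenyl arrangement, and only the 3,5-dichlorophenyl group gives a low number; no accompanying measurement speaks to what lies behind these differences.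

The compounds shown leave open whether bromine or methyl groups, in place of the two chlorines of the 3,5-dichlorophenyl group, would keep the number of compound 1 or lose it as the fluorines do. Also open, going by these compounds, is how a single chlorine on this ring would compare with either dichlorophenyl group, which would show whether both chlorines are needed at all.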